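Two Five-Membered Rings Return in Place of a Seven-Membered Ring

The source may report more compounds than this note shows. Statements on the series, on what has been measured and on what is new or still open speak of the compounds shown alone.

Two measured compounds anchor this comparison. Compound 1 `Cc1cc(S(=O)(=O)N2C=CNC(=O)[C@H]2CC(=O)N2CC[C@H](N3CCCC3)C2)c(C)cc1Cl` and compound 2 `Cc1cc(S(=O)(=O)N2C=CNC(=O)[C@H]2CC(=O)N2CCCC(N(C)C)CC2)c(C)cc1Cl` share a core and differ only in the amine-bearing group attached to the carbonyl carbon. In an in vitro functional assay on cells for antagonist activity at B1 bradykinin receptor (Homo sapiens), read by luminescence and calcium flux, with a stated time of 2 h (on this read-out lower numbers stand for stronger inhibition and higher numbers for weaker inhibition), compound 1 gives 19 nM, while compound 2 gives 2.7 nM, the lowest of the two numbers; the step between them is a 7.0-fold lower number from compound 1 to compound 2 (0.85 log units; beyond the scatter). Compound 3 `Cc1cc(S(=O)(=O)N2C=CNC(=O)[C@H]2CC(=O)N2CCC3(CCN(C)C3)C2)c(C)cc1Cl` is the next candidate. Its difference from compound 2 is a group of 10 heavy atoms (8 carbon, 2 nitrogen; 2 five-membered non-aromatic rings with 1 hetero atom each) in place of a group of 10 heavy atoms (8 carbon, 2 nitrogen; one seven-membered non-aromatic ring with 1 hetero atom), on a carbonyl carbon. Among the measured compounds shown here, the one measured step that bears on this change is the move from compound 1 to compound 2, a 7.0-fold lower number from compound 1 to compound 2 (0.85 log units; beyond the scatter), in which a seven-membered ring replaced two five-membered rings and the number fell. Compound 3 reverses that exchange in kind, although the two five-membered rings it carries are not joined as in compound 1, so a full return to the number of compound 1 is not the only outcome. One therefore expects a step in this assay toward a higher number, smaller than the measured one: a 3.0-fold higher number from compound 2 to compound 3 (0.47 log units; beyond the scatter) is the expected change. For compound 3 the estimate in this assay is 8 nM, with an expected range from 2.5 nM to 25 nM.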

Compound 3, half-maximal inhibitory concentration: 1.53 nM
Compound 3: the middle estimate sits 5.2-fold (0.72 log units) above what was measured; measured number outside the range, below it.
By their numbers in this assay, from the lowest: compounds 3 and 2 (each within the scatter of the next); then compound 1.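

The seven-membered ring of compound 2 proves not to be required for a low number in this assay: the step to the group with 2 five-membered non-aromatic rings is a 1.8-fold lower number from compound 2 to compound 3 (0.25 log units; within the scatter), so compound 2 and compound 3 cannot be told apart, and compound 3 goes against the trend suggested by the earlier pair. The comparison with compound 1 is more telling, since both groups on the carbonyl carbon have the same heavy-atom count and the same printed ring description, yet the step is a 12-fold lower number from compound 1 to compound 3 (1.09 log units; beyond the scatter), which shows that at this position the way the two rings are joined matters more than their number and size. No supporting measurement is available to explain either step.

On these data alone, whether a piperidine or an open-chain diethylamino group on the same carbonyl carbon would give numbers like those of compound 2 and compound 3 remains open. Also open, as far as these compounds go, is whether a primary amine in place of the tertiary amine of the entering group would hold the number of compound 3.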